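Chloro to methyl on the pendant phenyl: compound 2 to 3

A few compounds are considered here, and "the series" means these few. Any claim that something is new, unique, unknown or untested is made for them only; others in the source may bear on it.

Measured so far:
compound 1 `COc1ccc(CN2C(=O)C(=O)c3cc(-c4cccc(OC)c4)ccc32)cc1`: 1890 nM
compound 2 `COc1ccc(CN2C(=O)C(=O)c3cc(-c4ccc(Cl)cc4)ccc32)cc1`: 380 nM

Both compounds were read in a functional assay on HepG2 cells (Homo sapiens) for antiproliferative activity, read by MTT assay, with a stated time of 48 h; a higher number here means a weaker inhibitor, a lower number a stronger inhibitor. Among the measured compounds shown here, compound 2 stands lowest of the two numbers; its nearest neighbour is compound 1, and the single measured step, a 5.0-fold lower number from compound 1 to compound 2 (0.70 log units; beyond the scatter), separates them, a modest step that lies beyond the scatter.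

Compound 3 `COc1ccc(CN2C(=O)C(=O)c3cc(-c4ccc(C)cc4)ccc32)cc1` has not been measured. It differs from compound 2 in one place: methyl in place of chloro on an aromatic carbon. For the measured compounds named here, no measured step bears directly on this exchange. Going by the values given here, the only step in hand, a 5.0-fold lower number from compound 1 to compound 2 (0.70 log units; beyond the scatter), replaces one substituted phenyl by a differently substituted one, and so does not isolate the chloro-to-methyl swap. The data give nothing to separate chloro from methyl on this ring.

A step within the usual scatter is therefore expected, a 1.4-fold higher number from compound 2 to compound 3 (0.16 log units; within the scatter). Compound 3 is estimated to give about 550 nM in this assay, with an expected range from 200 nM to 1500 nM.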

Compound 3, half-maximal inhibitory concentration: > 10000 nM
Compound 3: a limit, no number; the forecaster's own chance of this, stated with the estimate: 5%; at least 18-fold (1.25 log units) between middle value and limit.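

In this assay compound 3 gives a limit and not a number: the limit of > 10000 nM in this assay, at which 1 of the 3 values shown sits.

Among the compounds shown here, the exchange of chloro for methyl, para to a large group on the pendant phenyl, gives an at least 26-fold higher number from compound 2 to compound 3 (1.42 log units; beyond the scatter), so this position clearly separates two groups that the earlier compounds gave no means of telling apart. The 4-methylphenyl group also falls behind the 3-methoxyphenyl group, with an at least 5.2-fold higher number from compound 1 to compound 3 (0.72 log units; beyond the scatter), which places the three pendant groups in the order 4-chlorophenyl, 3-methoxyphenyl, 4-methylphenyl in this assay, and shows that the pendant phenyl's substituent can decide whether any activity is read at all within the range tested.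

From the compounds shown here alone, how an amine, a carboxylic acid or an ethyl chain would read in place of chloro stays open, as does the plain phenyl ring without a substituent, so it cannot yet be said whether chloro is unusually favourable or methyl unusually poor. The full size of both steps also stays unknown, since compound 3 is held only as a limit, and nothing shown explains why these two groups part so sharply.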